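The source may hold more compounds than are shown below. What is called first, only, known or untested is meant among the compounds shown, and "the series" means these compounds.

Of the compounds shown here, two sharing one core have been measured so far. In a functional assay on a cell-free system (plasma, Homo sapiens), with a stated time of 3 min (on this read-out higher numbers stand for weaker inhibition and lower numbers for stronger inhibition), compound 2 `O=C(NCc1cc(Cl)ccc1-n1cnnn1)[C@@H]1C[C@@H]2C[C@@H]2N1C(=O)[C@H](O)c1ccccc1` gives 620 nM, and compound 1 `O=C(NCc1cc(Cl)ccc1-n1cnnn1)[C@@H]1C[C@@H]2C[C@@H]2N1C(=O)[C@H](O)c1cccc(Cl)c1` gives 1000 nM, so the two lie within the usual scatter of each other. Compound 3 `COC(C)(C)[C@@H](O)C(=O)N1[C@H](C(=O)NCc2cc(Cl)ccc2-n2cnnn2)C[C@@H]2C[C@@H]21` keeps the core but exchanges an aromatic group for an open chain: 1-methoxy-1-methylethyl in place of phenyl on a saturated chain carbon bound to a carbonyl carbon and an oxygen on a saturated carbon. Within the data shown here, only one measured step bears on this change, and only indirectly. It is a 1.6-fold lower number from compound 1 to compound 2 (0.21 log units; within the scatter), where hydrogen takes the place of chloro on an aromatic carbon of that same group. This step stays within the scatter, but the ring remains in both compounds, so it says little about removing the ring altogether. Among the measured compounds shown here, no measured compound lacks that ring, which leaves the outcome uncertain. A modest rise in the number, meaning weaker inhibition, is expected, and the expected change is a 2.4-fold higher number from compound 2 to compound 3 (0.38 log units; beyond the scatter). For compound 3 the estimate is 1500 nM, with an expected range from 350 nM to 6000 nM.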

Compound 3, half-maximal inhibitory concentration: 1000 nM
For compound 3 the middle estimate is 1.5-fold (0.18 log units) above the measured one; the measured number falls inside the stated range.
By their numbers in this assay, from the lowest: compounds 2, 1 and 3 (each within the scatter of the next).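

In this assay, an aromatic ring on this saturated chain carbon proves not to be needed to stay within the scatter: putting 1-methoxy-1-methylethyl in place of phenyl gives a 1.6-fold higher number from compound 2 to compound 3 (0.21 log units; within the scatter) and putting it in place of 3-chlorophenyl gives no change at the digits printed from compound 1 to compound 3 (within the scatter) in this series. The earlier pair varied only a chloro on a ring that both compounds keep, whereas compound 3 is the first case shown with an open chain at this place, and none of the three compounds can be told apart from its neighbours in this assay. No supporting measurement is available to explain why a ring and this open chain read alike here.

The compounds shown leave open how far this tolerance reaches, for example to an open chain carrying an amine or a carboxylic acid, or to a longer chain than 1-methoxy-1-methylethyl. They also leave open whether the oxygen of the chain matters, a question that a tert-butyl group, made of carbon only, could address at this same place.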